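The compounds below may be only part of what the source reports. "The series", "measured", "known", "first", "only" and "open" are said of these compounds alone.

In a functional assay on NALM-6 cells (Homo sapiens) for cytotoxicity, with a stated time of 72 h (on this read-out higher numbers stand for an effect only at larger amounts of compound and lower numbers for an effect already at smaller amounts), three compounds have been measured so far. Compound 1 `C=C[C@@](C)(/C=C/c1ccc(O)cc1)CCC1OC1(C)C` gives > 43400 nM, which is a limit of the assay and not a number. Compound 2 `C=C[C@@](C)(/C=C/c1ccc(O)cc1)CC/C=C/C#N` gives > 43400 nM, which is likewise a limit. That leaves a step that the two limits leave unreadable from compound 1 to compound 2, and this step concerns the chain, not the aromatic ring. Among the compounds with values here, compound 3 `C=C[C@@](C)(/C=C/c1ccc(O)c(C=O)c1)CCC=C(C)C` gives 11200 nM, the only true number in the set, so it has no measured neighbour with a number to be ranked against.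

The next compound, compound 4 `C=C[C@@](C)(/C=C/c1ccc(O)c(/C=C/C(=O)O)c1)CCC=C(C)C`, differs from compound 3 by 2-carboxyethenyl in place of formyl on an aromatic carbon, ortho to a hydroxy group. Within the data shown here, no measured step covers this exchange, so the size of the change cannot be read from the data. Among the measured compounds shown here, the only guide is the position of compound 3 at 11200 nM, with the rest of the set resting on (the limit of > 43400 nM in this assay, at which 2 of the 3 values shown sit). A modest move towards larger amounts is therefore expected, though a result within the scatter would not surprise. The expected change is a 2.0-fold higher number from compound 3 to compound 4 (0.29 log units; within the scatter). For compound 4 the estimated value is 22000 nM, with an expected range from 9000 nM to 43400 nM.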

Compound 4, half-maximal effective concentration: > 43400 nM
Compound 4 gave a limit, no number; the forecaster's own chance of this, stated with the estimate: 40%; middle value at least 1.9-fold (0.29 log units) from the limit.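

Within the data shown here, the exchange on this aromatic carbon, ortho to a hydroxy group, gives the first step in this assay that can be read: an at least 3.8-fold higher number from compound 3 to compound 4 (0.58 log units; beyond the scatter). Among these compounds, the earlier compounds offered only a change in the chain, and that step cannot be read, so this is the first sign that the aromatic position matters: with formyl there, compound 3 keeps a true number, whereas 2-carboxyethenyl in the same place does not give one. The step has a lower bound only, and its full size stays hidden, as compound 4 joins the other compounds at the limit of the assay: the limit of > 43400 nM in this assay, at which 3 of the 4 values shown sit.

The compounds shown leave open whether the loss belongs to the carboxylic acid or to the two-carbon ethenyl link that carries it, since no compound here has a methyl ester in that place or a carboxylic acid set directly on the aromatic carbon. They also leave open whether an amine or a hydroxymethyl group on this carbon would hold a number like that of compound 3, and what that carbon gives with no group on it at all.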